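Amine chain on an aromatic nitrogen of compound 1

The source may report more compounds than this note shows. Statements on the series, on what has been measured and on what is new or still open speak of the compounds shown alone.

Compound 1 `Cn1c(N)c(-c2nc3ccccc3[nH]2)c2nc(C#N)c(C#N)nc21` gives > 50000 nM in a functional assay on HL-60 cells (Homo sapiens) for antiproliferative activity, read by MTT assay, with a stated time of 48 h (a lower number here means a stronger inhibitor, a higher number a weaker inhibitor), which is a limit and not a number. Compound 1 thus stands at the limit of > 50000 nM in this assay, at which 1 of the 3 values shown sits.

Compound 4 `CN(C)CCCCn1c(-c2c(N)n(C)c3nc(C#N)c(C#N)nc23)nc2ccccc21` differs from it by 4-(dimethylamino)butyl in place of hydrogen on an aromatic nitrogen. In this assay, compound 2 `CN1CCN(CCCn2c(N)c(-c3nc4ccccc4[nH]3)c3nc(C#N)c(C#N)nc32)CC1` gives 750 nM and compound 3 `CCN(CC)CCCCn1c(N)c(-c2nc3ccccc3[nH]2)c2nc(C#N)c(C#N)nc21` gives 460 nM. The nearest evidence is an at least 66-fold lower number from compound 1 to compound 2 (1.82 log units; beyond the scatter) and an at least 100-fold lower number from compound 1 to compound 3 (2.03 log units; beyond the scatter), both large, while a 1.6-fold lower number from compound 2 to compound 3 (0.21 log units; within the scatter) stays within the scatter. Those chains enter on a saturated chain carbon, not on the aromatic nitrogen used here, so they bear only by analogy. A large step to a lower number is still expected, estimated as an at least 41-fold lower number from compound 1 to compound 4 (1.61 log units; beyond the scatter). For compound 4 the estimated value is 1200 nM, with an expected range of 250 nM to 8000 nM.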

Compound 4, half-maximal inhibitory concentration: 2270 nM
Beside the measured number, compound 4's estimate is 1.9-fold (0.28 log units) below it, within the range that was stated.
By their numbers in this assay, from the lowest: compounds 3 and 2 (each within the scatter of the next); then compound 4. At a limit, above all of these: compound 1.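

In this assay, 4-(dimethylamino)butyl on this aromatic nitrogen gives an at least 22-fold lower number from compound 1 to compound 4 (1.34 log units; beyond the scatter), so an amine chain at this position also goes with a large step, not only one entering on a saturated chain carbon. Compound 1 holds a limit and not a number, so the size of this step is only a bound: the limit of > 50000 nM in this assay, at which 1 of the 4 values shown sits.

Open, going by these compounds, is how a shorter amine chain, a morpholine-ending chain or a carboxylic acid would read on this aromatic nitrogen. Also open, on these data alone, is whether the basic amine itself is needed here, which a plain butyl chain would test.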